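Hydroxytyrosol ester series: shortening the acyl chain to butanoyl

The source may report more compounds than this note shows. Statements on the series, on what has been measured and on what is new or still open speak of the compounds shown alone.

Compound 3 `CCCCCCCC(=O)OCCc1ccc(O)c(O)c1` gives 104000 nM in a toxicity assay on MRC5 cells (Homo sapiens) for inhibition, read by MTT assay, with a stated time of 72 h (a higher number here means a weaker inhibitor, a lower number a stronger inhibitor), the highest of the two numbers measured, with compound 2 `CCCCCCCCCC(=O)OCCc1ccc(O)c(O)c1` nearest at 71100 nM, a gap within the scatter. Compound 1 `CC(=O)OCCc1ccc(O)c(O)c1` gives only a limit of the assay, > 50000 nM, and so no number at all (the limit of > 50000 nM in this assay, at which 1 of the 3 values shown sits).

Compound 4 `CCCC(=O)OCCc1ccc(O)c(O)c1` is the next member: hydrogen in place of butyl on a saturated chain carbon, three bonds along the chain from a carbonyl carbon.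

Among the measured compounds shown here, two measured steps bear on this change. The step that the limit leaves unreadable from compound 1 to compound 3 runs the same way, a shorter chain to a longer one, but the limit on compound 1 leaves its size unreadable. The step of a 1.5-fold higher number from compound 2 to compound 3 (0.17 log units; within the scatter) is the same kind of shortening one position further out and lies within the scatter. Taken together, no step beyond the scatter can be asserted for compound 4, though a drift toward a higher number, that is weaker inhibition, remains possible and the limit cannot be ruled out.

Compound 4 is therefore expected at about 140000 nM, within 60000 nM to 350000 nM, which means an estimated step of a 1.3-fold higher number from compound 3 to compound 4 (0.13 log units; within the scatter).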

Compound 4, half-maximal inhibitory concentration: 71500 nM
Beside the measured number, compound 4's estimate is 2.0-fold (0.29 log units) above it, and the stated range covers the measured number.
By their numbers in this assay, from the lowest: compounds 2, 4 and 3 (each within the scatter of the next).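

In this assay, the change at this position, three bonds along the chain from a carbonyl carbon, gives a 1.5-fold lower number from compound 3 to compound 4 (0.16 log units; within the scatter), and the larger cut of hexyl to hydrogen gives a 1.0-fold higher number from compound 2 to compound 4 (0.00 log units; within the scatter). Among the compounds shown here, with compound 4 added, the three esters with readable values all lie within the scatter of one another, so removing either butyl or hexyl at this position produces no step that can be claimed. The step from compound 1 to compound 4 cannot be read because compound 1 gives only a limit: the limit of > 50000 nM in this assay, at which 1 of the 4 values shown sits.

On these data alone, whether any change to the acyl chain can move the number beyond the scatter remains open. As far as these compounds go, the effect in this assay of a longer chain, or of an amine or a carboxylic acid on the acyl chain, also remains open.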